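A Second Chloro Group on Two Related Cores

This account rests on a few compounds, and the source may have more. Where it says the series, first, only, none or still open, it means among the compounds named here.

In an assay on cells for inhibition of Amine oxidase [flavin-containing] A (Homo sapiens), read by fluorescence, with stated times of 30 min and 15 min (a higher number here means a weaker inhibitor, a lower number a stronger inhibitor), compound 1 `Cn1c(=O)[nH]c2ccc(OCc3ccc(Cl)cc3)cc21` gives only a limit, > 500000 nM. Compound 2 `Cn1c(=O)[nH]c2ccc(OCc3ccc(Cl)c(Cl)c3)cc21` likewise gives only a limit, > 500000 nM. The change between them is chloro in place of hydrogen on an aromatic carbon, and the step that the two limits leave unreadable from compound 1 to compound 2 has no readable size, since both values sit at a limit. Compound 3 `CC1(C)C(=O)Nc2ccc(OCc3cccc(Cl)c3)cc21` rests on a different core; the difference between the two cores is not broken down here. In this assay compound 3 gives only a limit, > 500000 nM. Compound 4 `CC1(C)C(=O)Nc2ccc(OCc3ccc(Cl)c(Cl)c3)cc21`, not yet measured, differs from compound 3 by chloro in place of hydrogen on an aromatic carbon. This is the same kind of change as from compound 1 to compound 2, though there the entering chloro group stands meta to a large group and here para to it. Because (the limit of > 500000 nM in this assay, at which 3 of the 3 values shown sit), the measured step offers no size to build on. The expected step is a step that the limit leaves unreadable from compound 3 to compound 4. Compound 4 is estimated at 800000 nM.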

Compound 4, half-maximal inhibitory concentration: > 500000 nM
Compound 4 was reported as a limit; the forecaster's own chance of this, stated with the estimate: 85%; the middle value does not contradict the limit.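

No step can be read between compound 3 and compound 4, because both values are limits, not numbers: the limit of > 500000 nM in this assay, at which 4 of the 4 values shown sit. The compounds shown leave open whether either core can give a measurable value in this assay at all.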